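A few compounds are considered here, and "the series" means these few. Any claim that something is new, unique, unknown or untested is made for them only; others in the source may bear on it.

Working notes on the series.

Of the compounds shown here, two have been measured in a functional assay on UACC-62 cells (Homo sapiens) for antiproliferative activity; a lower number here means a stronger inhibitor of growth, a higher number a weaker inhibitor of growth. Compound 1, `CCOC(=O)C[C@H]1[C@@H](O[Si](C)(C)C(C)(C)C)[C@H](n2cnc3c(NC(=O)Nc4ccccc4)ncnc32)O[C@@H]1COC(=O)NC`, gives 15.8 nM. Compound 2, `CNC(=O)NC[C@H]1O[C@@H](n2cnc3c(NC(=O)Nc4ccccc4)ncnc32)[C@H](O[Si](C)(C)C(C)(C)C)[C@@H]1CC(=O)N(C)OC`, gives 41.9 nM, the higher of the two numbers; its gap to compound 1 lies beyond the usual scatter. Going by the values given here, compound 1 and compound 2 differ from each other in more than one place, so no single step connects them and only their two values can be compared.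

Compound 3, `CCOC(=O)C[C@H]1[C@@H](O[Si](C)(C)C(C)(C)C)[C@H](n2cnc3c(NC(=O)Nc4ccccc4)ncnc32)O[C@@H]1CNC(=O)NC`, has not yet been measured in this assay. It follows from compound 2 by one change: ethoxy in place of methoxy(methyl)amino on a carbonyl carbon. The group that enters is the same ethoxycarbonyl found in compound 1; compound 3 otherwise keeps the methylurea chain of compound 2.

Among the compounds with values here, with no measured pair that isolates this change, the expectation rests on the two values shown. Compound 3 is expected to give a somewhat lower number than compound 2, a step of a 1.9-fold lower number from compound 2 to compound 3 (0.28 log units; within the scatter), since compound 1 with the ethoxycarbonyl group gives 15.8 nM. Compound 3 is thus estimated at 22 nM, with a range from 10 nM to 50 nM.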

Compound 3, concentration for 50% growth inhibition: > 100 nM
Compound 3 ended at the assay's limit; the forecaster's own chance of this, stated with the estimate: 2%; middle value at least 4.5-fold (0.65 log units) away from the limit.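

In this assay compound 3 gives > 100 nM, a limit of the assay and not a number, so both steps read from it are bounds only: the limit of > 100 nM in this assay, at which 1 of the 3 values shown sits. On the carbonyl carbon, ethoxy in place of methoxy(methyl)amino, with the methylurea chain kept, gives an at least 2.3-fold higher number from compound 2 to compound 3 (0.37 log units; beyond the scatter), so with this chain the ethoxycarbonyl group brings no gain and the methoxy(methyl)carbamoyl compound holds the lower number. On the saturated chain carbon bound to a saturated ring carbon, (methylcarbamoyl)amino in place of (methylcarbamoyl)oxy, with the ethoxycarbonyl group kept, gives an at least 6.3-fold higher number from compound 1 to compound 3 (0.80 log units; beyond the scatter), which shows that the low number of compound 1 does not survive this single change.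

As far as these compounds go, whether methoxy(methyl)amino on the carbonyl carbon would also give the lower number alongside the (methylcarbamoyl)oxy chain remains open, so the two places cannot yet be judged apart from each other. Also open, from the compounds shown here alone, is what a carboxylic acid or a primary amide on that carbonyl carbon would give with either chain, and what a simple amine would give in place of the methylurea chain.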